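A few compounds are considered here, and "the series" means these few. Any claim that something is new, unique, unknown or untested is made for them only; others in the source may bear on it.

In a physicochemical assay for pharmacokinetics (on this read-out higher numbers stand for a longer-lived compound and lower numbers for a shorter-lived compound), compound 2 `O=C(NCc1ccccc1)N1C(=O)c2ccccc2S1(=O)=O` gives 1.02 h and compound 3 `O=C(NCC1CCCCC1)N1C(=O)c2ccccc2S1(=O)=O` gives 0.963 h, two numbers within the scatter of each other. Compound 1 `O=C(NCc1ccccc1Br)N1C(=O)c2ccccc2S1(=O)=O` gives 0.253 h, clearly short of compound 2. The change to follow leads to compound 4 `O=C(NCc1ccccc1C(F)(F)F)N1C(=O)c2ccccc2S1(=O)=O` and is trifluoromethyl in place of hydrogen on an aromatic carbon, ortho to a large group.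

The closest measured guide is a 4.0-fold higher number from compound 1 to compound 2 (0.61 log units; beyond the scatter), a modest step in which hydrogen replaces bromo on an aromatic carbon. Read backwards, it links a group on that ring to a lower number. a 3.8-fold higher number from compound 1 to compound 3 (0.58 log units; beyond the scatter) is similar in size but also exchanges the ring, while a 1.1-fold lower number from compound 2 to compound 3 (0.02 log units; within the scatter) stays within the scatter. Within the data shown here, no measured compound carries trifluoromethyl, so the bromo step is only a loose guide. A modest fall in this assay is still expected, and the expected change is a 2.9-fold lower number from compound 2 to compound 4 (0.46 log units; beyond the scatter). The estimate for compound 4 is 0.35 h, with an expected range from 0.15 h to 0.85 h.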

Compound 4, half-life: 0.187 h
Estimate against measurement, compound 4: 1.9-fold (0.27 log units) above; the range from low to high includes it.
By their numbers in this assay, from the lowest: compounds 4 and 1 (each within the scatter of the next); then compounds 3 and 2 (each within the scatter of the next).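

In this assay, among these compounds, trifluoromethyl on this aromatic carbon gives a 5.5-fold lower number from compound 2 to compound 4 (0.74 log units; beyond the scatter), so bromo is no longer the only group seen to go with a shorter half-life than hydrogen on this ring. Exchanging one group for the other gives a 1.4-fold lower number from compound 1 to compound 4 (0.13 log units; within the scatter), so this assay does not separate trifluoromethyl from bromo. Nothing measured here explains the fall seen with either group.

The compounds shown leave open whether any group on this carbon would lower the number, or whether this fall is limited to bromo and trifluoromethyl. A methyl group, a methoxy group or a hydroxyl group at the same place would show whether the half-life of compound 2 can be kept with something other than hydrogen there.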